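Pyridin-3-yl in Place of 3-Sulfamoylphenyl

This account rests on a few compounds, and the source may have more. Where it says the series, first, only, none or still open, it means among the compounds named here.

- Compound 1 `CC(C)n1ncc2c(C(=O)Nc3cccc(F)c3)cc(-c3cccs3)nc21`: > 200000 nM, a limit and not a number
- Compound 2 `CC(C)n1ncc2c(C(=O)Nc3ccccc3S(N)(=O)=O)cc(-c3cccs3)nc21`: 25000 nM
- Compound 3 `CC(C)n1ncc2c(C(=O)Nc3cccc(S(N)(=O)=O)c3)cc(-c3cccs3)nc21`: 25000 nM

In an ADME assay on LLC-MK2 cells (Macaca mulatta) for cytotoxicity, read by spectrophotometry and crystal violet staining, with a stated time of 4 days (a lower number here means that less compound is tolerated, a higher number that more compound is tolerated), compound 3 gives 25000 nM, and the comparison with its closest neighbour shows no change at the digits printed from compound 2 to compound 3 (within the scatter). Compound 4 `CC(C)n1ncc2c(C(=O)Nc3cccnc3)cc(-c3cccs3)nc21` carries pyridin-3-yl in place of 3-sulfamoylphenyl on an amide-type nitrogen. Among the measured compounds shown here, two measured steps bear on this change, since both bring in a sulfamoyl group: an at least 8.0-fold lower number from compound 1 to compound 2 (0.90 log units; beyond the scatter) and an at least 8.0-fold lower number from compound 1 to compound 3 (0.90 log units; beyond the scatter). For the measured compounds named here, no measured compound carries pyridin-3-yl, so these steps guide the expectation only loosely. With the sulfamoyl group gone, a higher number of similar size, beyond the scatter, is expected in this assay. The expected change is a 4.0-fold higher number from compound 3 to compound 4 (0.60 log units; beyond the scatter). For compound 4 the estimated value is 100000 nM, within an expected range from 30000 nM to 200000 nM.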

Compound 4, half-maximal cytotoxic concentration: > 200000 nM
Compound 4 was reported as a limit; the forecaster's own chance of this, stated with the estimate: 35%; middle value at least 2.0-fold (0.30 log units) from the limit.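

In this assay, pyridin-3-yl on the amide-type nitrogen gives an at least 8.0-fold higher number from compound 3 to compound 4 (0.90 log units; beyond the scatter), and the same group in place of 2-sulfamoylphenyl gives an at least 8.0-fold higher number from compound 2 to compound 4 (0.90 log units; beyond the scatter). Among the compounds shown, the lower numbers occur only with a sulfamoylphenyl group, and a second group without sulfamoyl now joins 3-fluorophenyl at the top of the range. Compound 4 is reported as a limit and not a number, as is compound 1, and the step between them cannot be read: the limit of > 200000 nM in this assay, at which 2 of the 4 values shown sit.

As far as these compounds go, whether an amine or a carboxylic acid in place of sulfamoyl would also give the lower number remains open. So does the true tolerated concentration of compound 4 beyond its limit.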